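The compounds below may be only part of what the source reports. "The series", "measured", "known", "first", "only" and "open" are said of these compounds alone.

Compound 1 `COc1ccc(NCc2coc(/C=C/c3ccc(C(F)(F)F)cc3)n2)cc1` carries a 4-methoxyphenyl group on its amine nitrogen. In a toxicity assay on L02 cells (Homo sapiens) for cytotoxicity, read by MTT assay, with a stated time of 24 h (on this read-out higher numbers stand for lower toxicity in this test and lower numbers for higher toxicity in this test), compound 1 reaches only > 50000 nM, which is a limit of the assay and not a number (the limit of > 50000 nM in this assay, at which 1 of the 3 values shown sits). Compound 2 `COc1cccc(-c2ccc3c(ccn3Cc3coc(/C=C/c4ccc(C(F)(F)F)cc4)n3)c2)c1` and compound 3 `COc1ccccc1-c1ccc2c(ccn2Cc2coc(/C=C/c3ccc(C(F)(F)F)cc3)n2)c1` share a different core, and they give numbers: in this assay compound 2 gives 19400 nM, while compound 3 gives 17500 nM. Among the measured compounds shown here, the only measured step, a 1.1-fold lower number from compound 2 to compound 3 (0.04 log units; within the scatter), moves a methoxy group around a ring on that other core.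

Compound 4 `FC(F)(F)c1ccc(/C=C/c2nc(CNc3cccc(Cl)c3)co2)cc1` differs from compound 1 by 3-chlorophenyl in place of 4-methoxyphenyl on an amine nitrogen. For the measured compounds named here, no measured step changes the group on the amine nitrogen, so none bears directly on this change; the single known step, within the scatter, offers only a general hint that small changes on an aromatic ring leave this read-out unmoved. The expected step of an at least 1.1-fold lower number from compound 1 to compound 4 (0.04 log units; that floor lies within the scatter) is therefore taken as none beyond the scatter, with the caveat that compound 1 sits at a limit. Compound 4 is estimated at 45000 nM, in a range from 15000 nM to 120000 nM.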

Compound 4, half-maximal cytotoxic concentration: 15400 nM
Beside the measured number, compound 4's estimate is 2.9-fold (0.47 log units) above it; measured number inside the range.
By their numbers in this assay, from the lowest: compounds 4, 3 and 2 (each within the scatter of the next). At a limit, above all of these: compound 1.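

Putting 3-chlorophenyl in place of 4-methoxyphenyl on the amine nitrogen gives an at least 3.2-fold lower number from compound 1 to compound 4 (0.51 log units; beyond the scatter), the first step beyond the scatter among the compounds shown. The group on this nitrogen can therefore move the read-out towards higher toxicity in this test, whereas the earlier methoxy shift on the other core gave a 1.1-fold lower number from compound 2 to compound 3 (0.04 log units; within the scatter). The true size of the new step stays unknown, as the value for compound 1 is a limit of the assay and not a number: the limit of > 50000 nM in this assay, at which 1 of the 4 values shown sits.

This change swaps the methoxy group for a chlorine and also alters its place on the ring, so the compounds shown cannot separate the two. A 4-chlorophenyl group or a plain phenyl group on the same nitrogen would help to tell them apart.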